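Hydroxyphenyl ether in the aryloxy benzothiazole series

A few compounds are considered here, and "the series" means these few. Any claim that something is new, unique, unknown or untested is made for them only; others in the source may bear on it.

Compound 1 `CN(Cc1ccc(OCCCN)cc1)c1nc2ccc(Oc3ccccc3)cc2s1` gives 95000 nM in an assay on cells for inhibition of Voltage-dependent T-type calcium channel subunit alpha-1H (Homo sapiens), read by FLIPR and calcium flux, with stated times of 600 s and 300 s; on this read-out higher numbers stand for weaker inhibition and lower numbers for stronger inhibition. Compound 2 `CN(Cc1ccc(OCCCN)cc1)c1nc2ccc(Oc3ccc(F)cc3)cc2s1` gives 492000 nM in this assay, and compound 3 `CN(Cc1ccc(OCCCN)cc1)c1nc2ccc(Oc3cccc(C(F)(F)F)c3)cc2s1` gives 239000 nM. Among these three numbers compound 3 stands second highest: it lies a 2.1-fold lower number from compound 2 to compound 3 (0.31 log units; beyond the scatter) and sits a 2.5-fold higher number from compound 1 to compound 3 (0.40 log units; beyond the scatter). The other step, a 5.2-fold higher number from compound 1 to compound 2 (0.71 log units; beyond the scatter), is of the same modest order.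

Compound 4 `CN(Cc1ccc(OCCCN)cc1)c1nc2ccc(Oc3ccc(O)cc3)cc2s1` has not yet been measured. It differs from compound 3 in one place: 4-hydroxyphenyl in place of 3-(trifluoromethyl)phenyl on an oxygen on an aromatic ring. For the measured compounds named here, two measured steps bear on this change. The removal of the trifluoromethyl reverses a 2.5-fold higher number from compound 1 to compound 3 (0.40 log units; beyond the scatter), which on its own would point toward the number of compound 1. The entry of a substituent on the new phenyl recalls a 5.2-fold higher number from compound 1 to compound 2 (0.71 log units; beyond the scatter), where the only other substituent at a single position on this ring gave a weaker inhibition. Going by the values given here, no measured compound carries a hydroxyl on this ring, so the direction of that part is open. Taken together, compound 4 is expected to land near the number of compound 1 or somewhat above it, a step of a 1.6-fold lower number from compound 3 to compound 4 (0.20 log units; within the scatter) in this assay. The estimate for compound 4 is 150000 nM, with a range from 50000 nM to 500000 nM.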

Compound 4, half-maximal inhibitory concentration: 165000 nM
Compound 4: middle estimate off by 1.1-fold (0.04 log units), on the low side; low and high end bracket the measured number.
By their numbers in this assay, from the lowest: compounds 1, 4 and 3 (each within the scatter of the next, the first and the last beyond it); then compound 2.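

In this assay, 4-hydroxyphenyl in place of 3-(trifluoromethyl)phenyl on the oxygen stays within the scatter (a 1.4-fold lower number from compound 3 to compound 4 (0.16 log units; within the scatter)), even though the entering group brings one hydrogen-bond donor and one acceptor and the leaving group has neither. Hydroxy in place of fluoro on an aromatic carbon gives a step beyond the scatter (a 3.0-fold lower number from compound 2 to compound 4 (0.47 log units; beyond the scatter)), whereas hydroxy in place of hydrogen stays within it (a 1.7-fold higher number from compound 1 to compound 4 (0.24 log units; within the scatter)), so among these single changes on this ring, the step from hydrogen to fluoro in compound 2 and the step from fluoro to hydroxy are the ones that clear the scatter, and hydroxy cannot be told apart from hydrogen here. No independent data accompany these numbers to account for any of these steps.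

Going by these compounds, it remains open how a methoxy, an amine or a carboxylic acid in place of the hydroxy would read in this assay, and a methoxy would also test whether the hydroxyl hydrogen matters to the number. Also open, on these data alone, is whether these steps would hold with a longer chain in place of the aminopropoxy chain.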